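A few compounds are considered here, and "the series" means these few. Any claim that something is new, unique, unknown or untested is made for them only; others in the source may bear on it.

In an assay on isolated protein (Cavia porcellus) with Sigma non-opioid intracellular receptor 1 (Homo sapiens) as the target, read by radioligand binding (a higher number here means a weaker inhibitor, a lower number a stronger inhibitor), compound 2, whose structure is `CN(C)CCCCCCCCCOc1ccc2oc(-c3ccccc3)cc(=O)c2c1`, gives 334 nM, the higher of the two numbers measured. Compound 1, whose structure is `O=c1cc(-c2ccccc2)oc2cccc(OCCCCCCCN3CCC(O)CC3)c12`, gives 36 nM in this assay, and the gap between the two lies beyond the usual scatter of repeated measurements, so compound 2 is the weaker inhibitor of the pair. Compound 3, whose structure is `O=c1cc(-c2ccccc2)oc2ccc(OCCCCCCN3CCNCC3c3ncccn3)cc12`, has not yet been tested. It differs from compound 2 in one place: 2-(pyrimidin-2-yl)piperazin-1-yl in place of 3-(dimethylamino)propyl on a saturated chain carbon, six bonds along the chain from an oxygen on an aromatic ring. Going by the values given here, no step between two measured compounds matches this change, so there is nothing measured that fixes its size. The expectation is a move toward a lower number, larger than the scatter, from compound 2 to compound 3 of about a 5.6-fold lower number from compound 2 to compound 3 (0.75 log units; beyond the scatter). For compound 3 in this assay the estimate is 60 nM, with a likely range from 12 nM to 300 nM.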

Compound 3, half-maximal inhibitory concentration: 1630 nM
Compound 3: the middle estimate sits 27-fold (1.43 log units) below what was measured; measured number outside the range, above it.
By their numbers in this assay, from the lowest: compound 1; then compound 2; then compound 3.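

In this assay, going by these compounds alone, putting 2-(pyrimidin-2-yl)piperazin-1-yl in place of 3-(dimethylamino)propyl on a saturated chain carbon, six bonds along the chain from an oxygen on an aromatic ring, gives a 4.9-fold higher number from compound 2 to compound 3 (0.69 log units; beyond the scatter) and this is the first step measured at this place. In this pair, a group with two six-membered rings and 12 heavy atoms, replacing an open-chain group of 6 heavy atoms, leaves compound 3 the weaker inhibitor. Nothing measured here explains why the number rises.

The swap changes the saturated ring, the pyrimidine ring and the size of the group all at once, so this single pair cannot show which of these matters. A plain piperazin-1-yl without the pyrimidine ring, or a morpholin-4-yl, at the same place would help separate those parts.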